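Catechol diterpenoid series: removal of one hydroxy group

The source may report more compounds than this note shows. Statements on the series, on what has been measured and on what is new or still open speak of the compounds shown alone.

Measured so far:
compound 1 `C=C1CCC[C@H]2[C@](C)(CC3=C(O)C(=O)C=C(OC)C3=O)[C@@H](C)CC[C@@]12C` — > 10000 nM
compound 2 `COC(=O)c1cc(C[C@H]2C(C)=CC[C@H]3C(C)(C)CCC[C@]23C)c(O)c(O)c1O` — > 10000 nM

Of the compounds shown here, two have been measured in a functional assay on PC-3 cells (Homo sapiens) for antiproliferative activity, read by MTT assay; a lower number here means a stronger inhibitor, a higher number a weaker inhibitor. For compound 1 the value > 10000 nM is a limit of the assay, not a number. For compound 2 the value > 10000 nM is likewise a limit, not a number. Within the data shown here, both values sit at the limit of > 10000 nM in this assay, at which 2 of the 2 values shown sit, so no order between the two compounds can be drawn and no step between measured compounds is available. Compound 2 therefore stands at the limit of the assay, and nothing in the shown numbers places it above or below compound 1.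

Compound 3 `COC(=O)c1cc(O)c(O)c(C[C@H]2C(C)=CC[C@H]3C(C)(C)CCC[C@]23C)c1` differs from compound 2 in one place: hydrogen in place of hydroxy on an aromatic carbon. Among the measured compounds shown here, no measured step informs this change; the expectation for compound 3 rests on compound 2 standing at the limit > 10000 nM. The step that the limit leaves unreadable from compound 2 to compound 3 is expected to be small, with no direction beyond the scatter. For compound 3 the estimate is 15000 nM, in the range 3000 nM to 60000 nM, and a further limit rather than a number is expected as the more likely outcome.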

Compound 3, half-maximal inhibitory concentration: > 10000 nM
Compound 3: no number, only a limit (the forecaster's own chance of this, stated with the estimate: 70%); the middle value is on the limit's open side.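

The change from compound 2 to compound 3, hydrogen in place of hydroxy on an aromatic carbon, gives no readable step, since each compound carries a limit and not a number: the limit of > 10000 nM in this assay, at which 3 of the 3 values shown sit.

The compounds shown leave open how strongly any of the three acts in this assay, and whether removing this hydroxy group changes that at all.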